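The source may report more compounds than this note shows. Statements on the series, on what has been measured and on what is new or still open speak of the compounds shown alone.

Of the compounds shown here, three that share one core have been measured in an ADME assay for metabolic stability, read by LC-MS, with a stated time of 3 h, at pH 6.5, tested at 50 uM; on this read-out lower numbers stand for a less stable compound and higher numbers for a more stable compound. Compound 1 `CCOC(=O)C1=C(S[C@@H]2CN[C@H](C(=O)Nc3cccc(C(=O)O)c3)C2)[C@H](C)[C@@H]2[C@@H]([C@@H](C)O)C(=O)N12` carries an ethyl ester on the core; in this assay compound 1 gives > 95%, which is a limit of the assay and not a number. Compound 2 `CCC(CC)C(=O)OCOC(=O)C1=C(S[C@@H]2CN[C@H](C(=O)Nc3cccc(C(=O)O)c3)C2)[C@H](C)[C@@H]2[C@@H]([C@@H](C)O)C(=O)N12` carries ((pentan-3-yl)carbonyl)oxy in place of methyl on a saturated chain carbon bound to an oxygen next to a carbonyl group; in this assay compound 2 gives > 95%, again a limit. Compound 3 `COC(=O)OCOC(=O)C1=C(S[C@@H]2CN[C@H](C(=O)Nc3cccc(C(=O)O)c3)C2)[C@H](C)[C@@H]2[C@@H]([C@@H](C)O)C(=O)N12` carries (methoxycarbonyl)oxy in place of that same methyl; in this assay compound 3 gives > 95%, also a limit. The steps a step that the two limits leave unreadable from compound 1 to compound 2, a step that the two limits leave unreadable from compound 1 to compound 3 and a step that the two limits leave unreadable from compound 2 to compound 3 therefore cannot be sized, because of the limit of > 95% in this assay, at which 3 of the 3 values shown sit. Compound 4 `COC(=O)OCOC(=O)C1=C(S[C@@H]2CN[C@H](C(=O)Nc3cccc(C(=O)OCOC(=O)OC)c3)C2)[C@H](C)[C@@H]2[C@@H]([C@@H](C)O)C(=O)N12` differs from compound 3 by ((methoxycarbonyl)oxy)methyl in place of hydrogen on an oxygen next to a carbonyl group. For the measured compounds named here, since none of the measured steps moved the read-out in a readable way, no step beyond the scatter is expected for a number no higher from compound 3 to compound 4 (the limit leaves the size open). Compound 4 is accordingly estimated at 95%, within a range from 75% to 99%, most likely reported once more as a limit.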

Compound 4, percent of the compound remaining: > 95%
Compound 4: only a limit was reported; the forecaster's own chance of this, stated with the estimate: 55%; the middle value sits exactly at the limit.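

In this assay compound 4 gives > 95%, which is a limit of the assay and not a number. The step from compound 3 to compound 4 therefore cannot be read, because both values are limits: the limit of > 95% in this assay, at which 4 of the 4 values shown sit.

The compounds shown leave open whether compounds 1, 2, 3 and 4 truly differ in this assay.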